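Methyl on the urea phenyl of a pyrimidinyl urea

The compounds below may be only part of what the source reports. "The series", "measured", "known", "first", "only" and "open" are said of these compounds alone.

Compound 1 `O=C(Nc1ccccc1)Nc1nc(Sc2c[nH]c3ccccc23)cc(N2CCCC2)n1` and compound 2 `O=C(Nc1ccccc1)Nc1nc(Nc2ccccc2)cc(Sc2c[nH]c3ccccc23)n1` share the core of compound 1, with a phenylurea and an indolylthio group on it. In a functional assay on A549 cells (Homo sapiens) for inhibition, with a stated time of 72 h (a higher number here means a weaker inhibitor, a lower number a stronger inhibitor), compound 1 gives 21200 nM. Compound 2 reaches only a limit of this assay, > 50000 nM, so its place among the numbers shown is an open range rather than a point. Among the measured compounds shown here, the step of an at least 2.3-fold higher number from compound 1 to compound 2 (0.37 log units; beyond the scatter) is the single measured change in the set, and the limit of > 50000 nM in this assay, at which 1 of the 2 values shown sits, is what bounds its size. Compound 3 `Cc1ccc(NC(=O)Nc2nc(Nc3ccccc3)cc(Sc3c[nH]c4ccccc34)n2)cc1` differs from compound 2 by methyl in place of hydrogen on an aromatic carbon. For the measured compounds named here, no measured step touches that part of the molecule, so nothing in the data speaks for a shift in this assay beyond the scatter in either direction. The estimate for compound 3 in this assay is 60000 nM, with a range from 20000 nM to 150000 nM, which amounts to an expected step that the limit leaves unreadable from compound 2 to compound 3.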

Compound 3, half-maximal inhibitory concentration: 23500 nM
The estimate for compound 3 lay 2.6-fold (0.41 log units) above the measured number, within the range that was stated.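

In this assay, the change from phenylcarbamoyl to (4-methylphenyl)carbamoyl gives an at least 2.1-fold lower number from compound 2 to compound 3 (0.32 log units; beyond the scatter). Among the compounds shown here, this is the first measured step on the urea phenyl, since the earlier pair differed only in the pyrrolidin-1-yl and anilino groups, and it shows that this ring position can move the number with a single added methyl. The step has only a lower bound on its size, and how far it really reaches stays unknown: the limit of > 50000 nM in this assay, at which 1 of the 3 values shown sits.

A single methyl does not show whether an ethyl, a methoxy or a carboxylic acid on the same carbon would move the number in the same direction. Also open, from the compounds shown here alone, is whether methyl at this position would give a comparable step with pyrrolidin-1-yl in place of the anilino group, as in compound 1.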